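A Bromine Added to the Benzyl Arm

The source may hold more compounds than are shown below. What is called first, only, known or untested is meant among the compounds shown, and "the series" means these compounds.

Three compounds that share an acetic acid side chain on a thiazole-like core have been measured in an in vitro assay on COS-7 cells for displacement of a labelled ligand from prostaglandin D2 receptor 2 (Homo sapiens); a higher number here means a weaker inhibitor, a lower number a stronger inhibitor. Compound 2 `COc1ccc(-c2nc(-c3ccccc3)c(CC(=O)O)s2)cc1` gives 820 nM in this assay. Compound 1 `COc1ccc(-c2nc(-c3ccc(Br)cc3)c(CC(=O)O)s2)cc1` differs from it only by bromo in place of hydrogen on an aromatic carbon, and in this assay compound 1 gives 390 nM, which is a 2.1-fold lower number from compound 2 to compound 1 (0.32 log units; beyond the scatter). Compound 3 `O=C(O)Cc1sc(Cc2ccccc2)nc1-c1ccc(F)cc1` gives 140 nM in this assay, the lowest number of the three; the difference between its core and the core of compound 2 is not broken down here.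

Compound 4 `O=C(O)Cc1sc(Cc2ccccc2Br)nc1-c1ccc(F)cc1` is the unmeasured member of the set. It differs from compound 3 by bromo in place of hydrogen on an aromatic carbon. This is the same kind of change as that from compound 2 to compound 1, but not the same: there the bromine sits para to a large group, while in compound 4 it sits ortho to a large group, and the ring that carries it is a benzyl rather than a phenyl.

For compound 3 to compound 4 a step of a 1.4-fold lower number from compound 3 to compound 4 (0.15 log units; within the scatter) is expected in this assay, resting on the earlier pair because a 2.1-fold lower number from compound 2 to compound 1 (0.32 log units; beyond the scatter) was modest, and the changed place makes that a loose guide. Compound 4 is therefore estimated to give 100 nM. The expected range for compound 4 runs from 45 nM to 220 nM.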

Compound 4, half-maximal inhibitory concentration: 700 nM
For compound 4 the middle estimate is 7.0-fold (0.85 log units) below the measured one, and the stated range ends below it.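

In this assay, the same swap of hydrogen for bromo on an aromatic carbon gave a 5.0-fold higher number from compound 3 to compound 4 (0.70 log units; beyond the scatter), so the number rose on this core where it had fallen on the earlier one, and the two steps clearly disagree: the same change on two cores in this assay, a 2.1-fold lower number (0.32 log units; beyond the scatter) from compound 2 to compound 1 and a 5.0-fold higher number (0.70 log units; beyond the scatter) from compound 3 to compound 4, 11-fold (1.02 log units) apart, beyond the scatter of two such steps This shows that, among these compounds, the result of adding bromo on one core is not a safe guide to its result on the other, not even for the direction of the step. It does not show what drives the disagreement, since the two pairs differ in several ways at once: the cores are different, the bromo in compound 4 sits ortho to a large group on a benzyl, and the bromo in compound 1 sits at a different place on a phenyl, so two pairs cannot separate these differences.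

Still open, as far as these compounds go, is whether the higher number of compound 4 belongs to that particular place, which could be tested by moving the bromo elsewhere on the benzyl ring of compound 3. Also open, from the compounds shown here alone, is whether a chloro or a methyl group at the same place would follow the bromo or behave differently.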